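Removing a Methyl from the Pyridine Ring of Compound 2

This account rests on a few compounds, and the source may have more. Where it says the series, first, only, none or still open, it means among the compounds named here.

Two amidrazone thiosemicarbazides have been measured in a functional assay on MCF7 cells (Homo sapiens) for cytotoxicity, read by MTT assay, with a stated time of 72 h; on this read-out lower numbers stand for stronger inhibition and higher numbers for weaker inhibition. Compound 1 `N/C(=N\NC(=S)N1CCCCC1)c1ccccn1` gives 8500 nM in this assay. Compound 2 `Cc1cccc(/C(N)=N/NC(=S)N2CCCC2)n1` gives 61800 nM in this assay, the higher of the two numbers; the gap between compound 2 and compound 1 lies beyond the scatter, though the two compounds differ in more than one place, so no single step can be read from them.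

The next compound, compound 3 `N/C(=N\NC(=S)N1CCCC1)c1ccccn1`, is reached from compound 2 by a single change: hydrogen in place of methyl on an aromatic carbon. Among the measured compounds shown here, no measured pair shows this exact step, so its size cannot be read off directly. Compound 1, which likewise carries no methyl on its aromatic ring, gives 8500 nM in this assay, and this supports an expectation that compound 3 will move toward a lower number than compound 2. The expected step of a 5.2-fold lower number from compound 2 to compound 3 (0.71 log units; beyond the scatter) is therefore a moderate decrease, beyond the scatter. Compound 3 is accordingly estimated at 12000 nM in this assay, with a plausible range from 4000 nM to 40000 nM.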

Compound 3, half-maximal inhibitory concentration: 3600 nM
Estimate against measurement, compound 3: 3.3-fold (0.52 log units) above; measured number outside the range, below it.
By their numbers in this assay, from the lowest: compound 3; then compound 1; then compound 2.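

In this assay the methyl on the aromatic carbon next to the ring nitrogen proves to matter a great deal: with hydrogen in its place, the data show a 17-fold lower number from compound 2 to compound 3 (1.23 log units; beyond the scatter) and compound 3 becomes the lowest of the three numbers. Among the compounds shown here, compound 3 also gives the first single-place reading on the thiocarbonyl carbon, where pyrrolidin-1-yl in place of piperidin-1-yl gives a 2.4-fold lower number from compound 1 to compound 3 (0.37 log units; beyond the scatter) and so a modest step beyond the scatter, set against the large step on the aromatic carbon. Nothing measured here explains why either change has the size it has.

The aromatic carbon is shown only with methyl and hydrogen, so it remains open whether a chlorine, a methoxy group or an ethyl group there would follow methyl or hydrogen. It also remains open whether the methyl step keeps its size with piperidin-1-yl on the thiocarbonyl carbon, and how a morpholin-4-yl or dimethylamino group at that carbon would compare with the two rings shown.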